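Working notes: cyclopropyl in place of (furan-2-yl)methyl

The compounds below may be only part of what the source reports. "The series", "measured", "known", "first", "only" and "open" are said of these compounds alone.

Measured compounds:
compound 1 `CCCSc1nc(Nc2ccc(OC)cc2)c2nc(Nc3ccccc3)sc2n1` — > 64000 nM
compound 2 `CCCSc1nc(NCc2ccco2)c2nc(Nc3ccccc3)sc2n1` — > 64000 nM

In a functional assay on MGC-803 cells (Homo sapiens) for antiproliferative activity, read by MTT assay, with a stated time of 72 h (on this read-out higher numbers stand for weaker inhibition and lower numbers for stronger inhibition), compound 1 gives > 64000 nM, which is a limit of the assay and not a number. Compound 2 gives > 64000 nM in this assay, again a limit rather than a number. Both values sit at the same place, namely (the limit of > 64000 nM in this assay, at which 2 of the 2 values shown sit). Among the compounds with values here, the single measured step is a step that the two limits leave unreadable from compound 1 to compound 2; its size is not readable, as both ends are limits.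

Compound 3 `CCCSc1nc(NC2CC2)c2nc(Nc3ccccc3)sc2n1` is the next member. It differs from compound 2 in one place: cyclopropyl in place of (furan-2-yl)methyl on a nitrogen on an aromatic ring. Within the data shown here, no measured step bears directly on this exchange, and the one step that exists gives no size to compare against. Two consecutive members of the series have given only limits, so a change beyond the scatter is not expected. The step from compound 2 to compound 3 is expected to be a number no higher from compound 2 to compound 3 (the limit leaves the size open), which is none beyond the scatter. Compound 3 is therefore estimated to give 64000 nM in this assay, with a range from 25000 nM to 150000 nM, most probably again reported as a limit.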

Compound 3, half-maximal inhibitory concentration: > 64000 nM
Compound 3: no number, only a limit; the forecaster's own chance of this, stated with the estimate: 75%; the middle value sits exactly at the limit.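

Compound 3 gives > 64000 nM, which is a limit of the assay and not a number. No step among compound 1, compound 2 and compound 3 can therefore be read: the limit of > 64000 nM in this assay, at which 3 of the 3 values shown sit.

The compounds shown leave open what number lies behind each limit, and whether any exchange on the nitrogen changes the antiproliferative activity at all.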